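Iodo in Place of Thiophen-3-yl on the Shared Core

This account rests on a few compounds, and the source may have more. Where it says the series, first, only, none or still open, it means among the compounds named here.

In a functional assay on HeLa S3 cells (Homo sapiens) for antiproliferative activity, read by XTT assay, with a stated time of 72 h (a lower number here means a stronger inhibitor, a higher number a weaker inhibitor), compound 1 `COc1ncnc2c1c(I)cn2[C@@H]1O[C@H](CO)[C@@H](O)[C@H]1O` gives 14300 nM.
Compound 2 `Cc1ncnc2c1c(-c1cc3ccccc3o1)cn2[C@@H]1O[C@H](CO)[C@@H](O)[C@H]1O` reaches only the limit > 20000 nM in this assay, which is a limit of the assay and not a number.
Compound 3 `Cc1ncnc2c1c(-c1ccsc1)cn2[C@@H]1O[C@H](CO)[C@@H](O)[C@H]1O` gives 14300 nM in this assay.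

Compound 3 stands level with compound 1 at the digits shown, the two within the scatter of each other. Among the measured compounds shown here, only one measured step bears on this series: an at least 1.3-fold lower number from compound 2 to compound 3 (0.14 log units; that floor lies within the scatter), a step that rests on a limit of > 20000 nM in this assay, at which 1 of the 3 values shown sits, and whose floor lies within the scatter, so it tells little about the size of a change at this carbon. The change to compound 4 `Cc1ncnc2c1c(I)cn2[C@@H]1O[C@H](CO)[C@@H](O)[C@H]1O` is iodo in place of thiophen-3-yl on an aromatic carbon. For the measured compounds named here, no measured step exchanges iodo for thiophen-3-yl, but compound 1 carries iodo at the same place and gives 14300 nM, level with compound 3. The step of a 1.0-fold lower number from compound 3 to compound 4 (0.01 log units; within the scatter) is therefore expected to stay within the scatter. Compound 4 is estimated at 14000 nM in this assay, with a range from 6000 nM to 30000 nM.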

Compound 4, half-maximal inhibitory concentration: 4080 nM
For compound 4 the middle estimate is 3.4-fold (0.54 log units) above the measured one; measured number below the stated range.
By their numbers in this assay, from the lowest: compound 4; then compounds 1 and 3 (each within the scatter of the next). At a limit, above all of these: compound 2.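

With the methyl kept on the shared core, iodo in place of thiophen-3-yl on this aromatic carbon gives a step beyond the scatter in this assay: a 3.5-fold lower number from compound 3 to compound 4 (0.54 log units; beyond the scatter). Iodo in place of 1-benzofuran-2-yl points the same way, with an at least 4.9-fold lower number from compound 2 to compound 4 (0.69 log units; beyond the scatter), but this step rests on a limit and not on a number: the limit of > 20000 nM in this assay, at which 1 of the 4 values shown sits. With iodo held in place, methyl in place of methoxy gives a 3.5-fold lower number from compound 1 to compound 4 (0.54 log units; beyond the scatter), so iodo alone does not set the number, and the group at the other substituted carbon of the shared core counts as well.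

From the compounds shown here alone, whether the gain is particular to iodo remains open, as bromo, chloro and an ethynyl group do not appear at this carbon. Also open, going by these compounds, is what an amine would do in place of the methyl.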